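The source may report more compounds than this note shows. Statements on the series, on what has been measured and on what is new or still open speak of the compounds shown alone.

Working notes on the series. Compound 1 `Clc1cccc(-c2cc3n(n2)CCCC3)c1` gives 77 nM in a functional assay on HEK293 cells for negative allosteric modulation of metabotropic glutamate receptor 5 (Rattus norvegicus), read by FLIPR and calcium flux, with a stated time of 170 s; a higher number here means a weaker inhibitor, a lower number a stronger inhibitor. Compound 2 `FC(F)(F)c1cccc(-c2cc3n(n2)CCCC3)c1` carries the change trifluoromethyl in place of chloro on an aromatic carbon and in this assay compound 2 gives 3990 nM, a step of a 52-fold higher number from compound 1 to compound 2 (1.71 log units; beyond the scatter). Compound 3 `N#Cc1ccc(CC(=O)c2nn3c(c2Cl)CCCC3)nc1` is built on a different core, and the difference between the two cores is not broken down here. In this assay compound 3 gives 108 nM, a number that lies within the scatter of that of compound 1. Compound 4 `N#Cc1ccc(CC(=O)c2nn3c(c2C(F)(F)F)CCCC3)nc1` carries the change (trifluoromethyl in place of chloro on an aromatic carbon). In compound 2 the change sits on an aromatic carbon of a six-membered aromatic ring of carbon only, meta to a group of 9 heavy atoms; in compound 4 it sits on an aromatic carbon of a five-membered aromatic ring with 2 nitrogen, part of a fused or bridged system of two rings, next to the ring atom that bears a fused ring and next to the ring atom that bears a large group. The two changes are thus of the same kind, not the same. Within the data shown here, the step from compound 3 to compound 4 is expected to be a 14-fold higher number from compound 3 to compound 4 (1.14 log units; beyond the scatter), resting on a 52-fold higher number from compound 1 to compound 2 (1.71 log units; beyond the scatter) as the only precedent. A smaller size is taken, as that precedent stands in another setting. Compound 4 is estimated at 1500 nM in this assay, with a range from 300 nM to 8000 nM.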

Compound 4, half-maximal inhibitory concentration: 7180 nM
Estimate against measurement, compound 4: 4.8-fold (0.68 log units) below; measured number inside the range.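

In this assay the new step is a 66-fold higher number from compound 3 to compound 4 (1.82 log units; beyond the scatter), and the change keeps its direction and its size from one core to the other: the same change on two cores in this assay, a 52-fold higher number (1.71 log units; beyond the scatter) from compound 1 to compound 2 and a 66-fold higher number (1.82 log units; beyond the scatter) from compound 3 to compound 4, 1.3-fold (0.11 log units) apart, within the scatter of two such steps. The higher number with trifluoromethyl in place of chloro therefore holds on both the core of compound 1 and the core of compound 3, although in compound 4 the change sits on an aromatic carbon of a five-membered aromatic ring with 2 nitrogen, part of a fused or bridged system of two rings. These two pairs, read in a single assay, do not show that the step would carry to any further core, and they do not explain why the change has this size.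

The compounds shown leave open how other groups on that aromatic carbon, such as bromo, methyl or methoxy, would compare with chloro and trifluoromethyl. They also leave open whether the step would keep its size with an amine or a carboxylic acid in place of the nitrile of compound 3.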